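Replacing the Amino-Acid Amide in Compound 2

The compounds below may be only part of what the source reports. "The series", "measured", "known", "first", "only" and "open" are said of these compounds alone.

Measured compounds:
Compound 1, `C#CC(C)OC(=O)c1ccc(C(CC)(CC)c2ccc(OCCC(O)(CC)CC)c(C)c2)n1CC`: 2650 nM
Compound 2, `CCC(C)C(NC(=O)c1ccc(C(CC)(CC)c2ccc(OCCC(O)(CC)CC)c(C)c2)n1CC)C(=O)O`: 860 nM

In an assay on cells for agonist activity at vitamin D3 receptor (Homo sapiens), with a stated time of 96 h (on this read-out lower numbers stand for an effect already at smaller amounts and higher numbers for an effect only at larger amounts of compound), compound 2 gives 860 nM, the lowest of the two numbers, and compound 1 gives 2650 nM. Going by the values given here, the one step between them, a 3.1-fold lower number from compound 1 to compound 2 (0.49 log units; beyond the scatter), exchanges an ester for an amino-acid amide on the carbonyl carbon.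

Compound 3, `CCn1c(C(=O)N(C)CCO)ccc1C(CC)(CC)c1ccc(OCCC(O)(CC)CC)c(C)c1`, differs from compound 2 by (2-hydroxyethyl)(methyl)amino in place of (1-carboxy-2-methylbutyl)amino on a carbonyl carbon. Among the compounds with values here, only the step of a 3.1-fold lower number from compound 1 to compound 2 (0.49 log units; beyond the scatter) bears on this change, and it bears only loosely: it shows that the group on this carbonyl carbon can move the number by a modest amount, and that the amide carrying a carboxylic acid stood best. Compound 3 keeps an amide but loses the carboxylic acid. The expected step of a 1.7-fold higher number from compound 2 to compound 3 (0.24 log units; within the scatter) therefore goes toward a higher number, though it may also stay within the scatter. Compound 3 is estimated at 1500 nM, with a range from 500 nM to 4500 nM.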

Compound 3, half-maximal effective concentration: 52.7 nM
Compound 3: middle estimate off by 28-fold (1.45 log units), on the high side; measured number outside the range, below it.
By their numbers in this assay, from the lowest: compound 3; then compound 2; then compound 1.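

In this assay, going by these compounds alone, (2-hydroxyethyl)(methyl)amino in place of (1-carboxy-2-methylbutyl)amino on the carbonyl carbon gives a 16-fold lower number from compound 2 to compound 3 (1.21 log units; beyond the scatter), so this position can move the number much further than the earlier compounds showed. A carboxylic acid in this group is therefore not needed for a low number, and among these three amide and ester groups, the smaller 5-heavy-atom group stands lowest. Against the ester, the same group gives a 50-fold lower number from compound 1 to compound 3 (1.70 log units; beyond the scatter), the widest step in the series.

The step changes several features at once, so the compounds shown do not separate the roles of the hydroxyl, the methyl on the amide nitrogen and the missing carboxylic acid, and they leave open how an amine or a longer hydroxyalkyl chain would fare here. No measurement offered here accounts for the size of this step.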